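Fluoro for Chloro on an Outer Benzyl Ring

This account rests on a few compounds, and the source may have more. Where it says the series, first, only, none or still open, it means among the compounds named here.

Compound 1 `N#Cc1c(Nc2ccccc2Cl)nc(SCc2cn(Cc3ccccc3Cl)nn2)nc1-c1ccccc1` and compound 2 `N#Cc1c(Nc2ccccc2F)nc(SCc2cn(Cc3ccccc3Cl)nn2)nc1-c1ccccc1` share one core, while compound 3 `Cc1ccc(Nc2nc(SCc3cn(Cc4ccc(Cl)cc4)nn3)nc(-c3ccccc3)c2C#N)cc1` carries another; the difference between the two cores is not broken down here. In a functional assay on B16-F10 cells (Mus musculus) for inhibition, read by MTT assay, with a stated time of 72 h (on this read-out higher numbers stand for weaker inhibition and lower numbers for stronger inhibition), compound 1 gives 8350 nM and compound 2 gives 5230 nM. The change fluoro in place of chloro on an aromatic carbon gave a 1.6-fold lower number from compound 1 to compound 2 (0.20 log units; within the scatter). In this assay compound 3 gives 15100 nM. Compound 4 `Cc1ccc(Nc2nc(SCc3cn(Cc4ccc(F)cc4)nn3)nc(-c3ccccc3)c2C#N)cc1` is not yet measured and differs from compound 3 by fluoro in place of chloro on an aromatic carbon. This is the same kind of change as before, but the place differs: here the group sits para to a large group, whereas in compound 2 it sits ortho to a large group. Compound 4 is expected to show a 1.3-fold lower number from compound 3 to compound 4 (0.12 log units; within the scatter) in this assay, an expectation that rests on a 1.6-fold lower number from compound 1 to compound 2 (0.20 log units; within the scatter). Compound 4 is therefore estimated at 11500 nM, with a range from 5000 nM to 28000 nM.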

Compound 4, half-maximal inhibitory concentration: 3040 nM
Compound 4: middle estimate off by 3.8-fold (0.58 log units), on the high side; measured number below the stated range.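

In this assay, the change gave a 5.0-fold lower number from compound 3 to compound 4 (0.70 log units; beyond the scatter), and its size did not carry over from one core to the other: the same change on two cores in this assay, a 1.6-fold lower number (0.20 log units; within the scatter) from compound 1 to compound 2 and a 5.0-fold lower number (0.70 log units; beyond the scatter) from compound 3 to compound 4, 3.1-fold (0.49 log units) apart, beyond the scatter of two such steps

Among the compounds shown here, of the two steps, only the one from 4-chlorobenzyl to 4-fluorobenzyl lies beyond the scatter, so the size of this exchange cannot be assumed to hold across cores. For the compounds shown here, the data do not show what sets the two steps apart, since the core and the place of the change differ together and each core offers only one pair.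

The compounds shown leave open what a bromo, methoxy or trifluoromethyl group would give at the same place. They also leave open whether the larger step would recur with an amide in place of the nitrile.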